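This account rests on a few compounds, and the source may have more. Where it says the series, first, only, none or still open, it means among the compounds named here.

Measured so far: compound 1 `[O-][S+](CCNC1CCN(CC(O)Cc2ccccc2)CC1)C(c1ccc(F)cc1)c1ccc(F)cc1` with 351 nM; compound 2 `O=C(C1CC1)N1CCC(NCCSC(c2ccc(F)cc2)c2ccc(F)cc2)CC1` with 46.4 nM.

In an assay on membranes from Cortex for displacement of a labelled ligand from Sigma non-opioid intracellular receptor 1 (Cavia porcellus), read by scintillation counting, with a stated time of 120 min (a higher number here means a weaker inhibitor, a lower number a stronger inhibitor), compound 1 gives the higher of the two numbers; compound 2 sits below it, and the gap between the two is beyond the scatter. Among the measured compounds shown here, no step between compounds that differ in one place is available, since compound 2 differs from compound 1 in more than one place.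

Compound 3 `CC(C)(C)C(=O)N1CCC(NCC[S+]([O-])C(c2ccc(F)cc2)c2ccc(F)cc2)CC1` is the next compound. Relative to compound 1 the change is (tert-butyl)carbonyl in place of 2-hydroxy-3-phenylpropyl on an amine nitrogen in a ring. Compound 2 also carries a carbonyl group on that ring nitrogen and gives 46.4 nM, a lower number than compound 1, but because it differs from compound 1 elsewhere as well, its value cannot be read as a step for this change alone. Still, it is the only pointer present, so the step to compound 3 is expected to run downward, likely by a moderate amount beyond the scatter, with wide uncertainty: the expected step is a 3.2-fold lower number from compound 1 to compound 3 (0.50 log units; beyond the scatter). For compound 3 the estimated value in this assay is 110 nM, expected to fall between 30 nM and 400 nM.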

Compound 3, inhibition constant: 11200 nM
Estimate against measurement, compound 3: 100-fold (2.01 log units) below; the measured number lies above the stated range.
By their numbers in this assay, from the lowest: compound 2; then compound 1; then compound 3.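

In this assay, among the compounds shown here, the amine nitrogen in a ring gives the first readable single-change step: (tert-butyl)carbonyl in place of 2-hydroxy-3-phenylpropyl gives a 32-fold higher number from compound 1 to compound 3 (1.50 log units; beyond the scatter) and a much weaker inhibitor. This position is therefore far from indifferent to the group it carries, and the core of compound 1 stays untouched in this step. The change removes the six-membered aromatic ring of carbon only and the hydrogen-bond donor of the leaving group, and it brings in a carbonyl with no ring, but nothing measured alongside these values accounts for the rise.

Compound 2 differs from compound 1 and from compound 3 in more than one place, and steps to it cannot be read. Still open, going by these compounds, is whether the carbonyl or the loss of the aromatic ring carries the step: a benzoyl group or a 3-phenylpropyl chain on that ring nitrogen would separate the two.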